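Pyridin-2-yl to 1,2-oxazol-3-yl: a step without footing

The source may report more compounds than this note shows. Statements on the series, on what has been measured and on what is new or still open speak of the compounds shown alone.

Three compounds share one core and differ only in the ring at its far end. Compound 1 `N=C(N)c1cccc(CN2CC[C@H](NS(=O)(=O)c3ccc(-c4ccncc4)cc3)C2=O)c1`, compound 2 `C[n+]1ccc(-c2ccc(S(=O)(=O)N[C@H]3CCN(Cc4cccc(C(=N)N)c4)C3=O)cc2)cc1` and compound 3 `N=C(N)c1cccc(CN2CC[C@H](NS(=O)(=O)c3ccc(-c4ccccn4)s3)C2=O)c1` have each been tested in an assay on isolated protein for inhibition of Trypsin II (Bos taurus); a lower number here means a stronger inhibitor, a higher number a weaker inhibitor. In this assay compound 1 reaches only a limit of the assay, > 2900 nM. Compound 2 likewise gives only a limit, > 2900 nM. Compound 3 also gives only a limit, > 2100 nM. For the measured compounds named here, the one measured step, a step that the two limits leave unreadable from compound 1 to compound 2, cannot be read in size because both of its ends sit at the limit of > 2900 nM in this assay, at which 2 of the 3 values shown sit. Compound 3 thus stands at the limit of > 2100 nM in this assay, at which 1 of the 3 values shown sits, with no number of its own.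

Compound 4 `N=C(N)c1cccc(CN2CC[C@H](NS(=O)(=O)c3ccc(-c4ccon4)s3)C2=O)c1` differs from compound 3 by 1,2-oxazol-3-yl in place of pyridin-2-yl on an aromatic carbon. Going by the values given here, no measured step bears on this change: the only step available is unreadable, and the three values carry no direction. So no step beyond the scatter can be expected in this assay, and a weak result remains the likeliest outcome. Compound 4 is therefore estimated at 5000 nM, within a range from 2000 nM to 30000 nM. The step this estimate means, a step that the limit leaves unreadable from compound 3 to compound 4, is only an expectation.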

Compound 4, inhibition constant: 1900 nM
The estimate for compound 4 lay 2.6-fold (0.42 log units) above the measured number; measured number below the stated range.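

In this assay compound 4 gives 1900 nM, the first real number among the compounds shown rather than a limit of the assay. Putting 1,2-oxazol-3-yl in place of pyridin-2-yl, on the aromatic carbon next to the ring sulfur, gives an at least 1.1-fold lower number from compound 3 to compound 4 (0.04 log units; that floor lies within the scatter), so this change can be read only as a floor, and that floor does not establish a real gain. The true size of the step stays unknown because compound 3 has no number of its own: the limit of > 2100 nM in this assay, at which 1 of the 4 values shown sits.

As far as these compounds go, it remains open how the number would move with other groups at this place, such as a phenyl ring, an amine or a carboxylic acid. From the compounds shown here alone, it is also open whether 1,2-oxazol-3-yl would give a readable number on the core of compound 1.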